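The compounds below may be only part of what the source reports. "The series", "measured", "known", "first", "only" and "open" are said of these compounds alone.

In a functional assay on HeLa cells (Homo sapiens) for antiproliferative activity, read by MTT assay, with a stated time of 72 h (a higher number here means a weaker inhibitor, a lower number a stronger inhibitor), compound 1 (`COc1ncc(-c2ccc3c(c2)N(c2ccc(C)cc2)C(=O)CO3)cc1NS(=O)(=O)c1ccc(F)cc1`) gives 4650 nM and compound 2 (`COc1ccc(N2C(=O)COc3ccc(-c4cnc(Cl)c(NS(=O)(=O)c5ccc(F)cc5)c4)cc32)cc1`) gives 8320 nM. Going by the values given here, these two numbers lie within the scatter of each other, so compound 1 stands level with the only other measured compound. Compound 3 (`COc1ncc(-c2ccc3c(c2)N(c2ccc(F)cc2)C(=O)CO3)cc1NS(=O)(=O)c1ccc(F)cc1`) differs from compound 1 in one place: fluoro in place of methyl on an aromatic carbon. Among the compounds with values here, no measured step shows this change, so no shift beyond the scatter is expected in this assay. The expected change is a 1.1-fold higher number from compound 1 to compound 3 (0.03 log units; within the scatter). For compound 3 the estimated value is 5000 nM, within an expected range of 2000 nM to 12000 nM.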

Compound 3, half-maximal inhibitory concentration: 10500 nM
Compound 3: middle estimate off by 2.1-fold (0.32 log units), on the low side; the measured number falls inside the stated range.
By their numbers in this assay, from the lowest: compounds 1, 2 and 3 (each within the scatter of the next, the first and the last beyond it).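

In this assay, going by these compounds alone, the place para to a large group proves sensitive to a single-atom exchange: 4-methylphenyl to 4-fluorophenyl gives a 2.3-fold higher number from compound 1 to compound 3 (0.35 log units; beyond the scatter) and is the only one-place step measured here. This modest step favours the methyl-bearing compound 1 over compound 3. Nothing measured here explains the shift. The compounds shown leave open how an amine or a carboxylic acid would fare at this place. They also leave open whether the same exchange would give a similar step on a different core.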